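A few compounds are considered here, and "the series" means these few. Any claim that something is new, unique, unknown or untested is made for them only; others in the source may bear on it.

Measured so far in a functional assay on the whole organism (Tail, strain ICR) with Mus musculus as the target, in the tail flick test, with a stated time of 90 min, at a dose of 25 umol/kg by the oral route; on this read-out lower numbers stand for a weaker effect and higher numbers for a stronger effect at the one dose given:
compound 1 `O=C(O)[C@@H]1CCCN1C(=O)CN(c1nc(Cl)nc2[nH]cnc12)C1CC1` gives 26%
compound 2 `O=C(CN(c1nc(Cl)nc2[nH]cnc12)C1CC1)NCC(=O)OCc1ccccc1` gives 27.2%
compound 3 `O=C(OCc1ccccc1)[C@@H]1CCCN1C(=O)CN(c1nc(Cl)nc2[nH]cnc12)C1CC1` gives 43.3%

Compound 1 stands lowest of the three numbers; compound 2 lies within the scatter of it, compound 3 beyond it. For the measured compounds named here, the single step measured in one place, a number 17.3 percentage points higher from compound 1 to compound 3 (beyond the scatter), is benzyl in place of hydrogen on an oxygen next to a carbonyl group. Compound 4 `O=C(CN(c1nc(Cl)nc2[nH]cnc12)C1CC1)N[C@@H](CO)C(=O)O` differs from compound 1 by (1-carboxy-2-hydroxyethyl)amino in place of 2-carboxypyrrolidin-1-yl on a carbonyl carbon. Going by the values given here, no measured step bears directly on this exchange: compound 1 and compound 4 both keep the carboxy group, whereas the one known step, a number 17.3 percentage points higher from compound 1 to compound 3 (beyond the scatter), is a change at the oxygen rather than at the carbonyl carbon. In this assay the expected step is therefore no change at the digits printed from compound 1 to compound 4 (within the scatter), none beyond the scatter. Compound 4 is estimated at 26%, with a range of 12% to 40%.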

Compound 4, a percentage reported as activity, at one dose (the size of the read-out at that dose, not a potency): 43.9%
The estimate for compound 4 lay 17.9 percentage points below the measured number, and the stated range ends below it.
By their numbers in this assay, from the lowest: compounds 1 and 2 (each within the scatter of the next); then compounds 3 and 4 (each within the scatter of the next).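

In this assay, the substituent on the carbonyl carbon affects the read-out: (1-carboxy-2-hydroxyethyl)amino in place of 2-carboxypyrrolidin-1-yl gives a number 17.9 percentage points higher from compound 1 to compound 4 (beyond the scatter) with the carboxy group kept. A step beyond the scatter from compound 1 therefore does not require benzyl on the oxygen. No measured evidence explains this step.
Opening the ring and adding the hydroxyl remain unseparated in this change. A (1-carboxyethyl)amino group on the same carbonyl carbon would separate them, while the benzyl ester of compound 4 would test whether the two changes add.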